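Aryl substitution in the shared core: estimating compound 4

The compounds below may be only part of what the source reports. "The series", "measured", "known", "first", "only" and "open" are said of these compounds alone.

Measured so far in a functional assay on NCI-H460 cells (Homo sapiens) for inhibition, read by sulforhodamine B assay, with a stated time of 48 h; on this read-out higher numbers stand for weaker inhibition of growth and lower numbers for stronger inhibition of growth:
compound 1 `CC1=CC[C@H](C(C)(C)NC(=S)N/N=C/c2ccccc2)CC1` gives 13000 nM
compound 2 `COc1ccc(/C=N/NC(=S)NC(C)(C)[C@H]2CC=C(C)CC2)cc1` gives 22500 nM
compound 3 `CC1=CC[C@H](C(C)(C)NC(=S)N/N=C/c2ccccc2O)CC1` gives 1900 nM

Compound 1 stands second highest of the three numbers: compound 2 lies nearest, a 1.7-fold higher number from compound 1 to compound 2 (0.24 log units; within the scatter), while compound 3 lies furthest, a 6.8-fold lower number from compound 1 to compound 3 (0.84 log units; beyond the scatter). Compound 4 `CC1=CC[C@H](C(C)(C)NC(=S)N/N=C/c2cccc(Cl)c2)CC1` differs from compound 1 by chloro in place of hydrogen on an aromatic carbon. Going by the values given here, no measured step introduces a chloro group, and none touches the position meta to a large group; the steps that bear on it are the other substitutions on the same ring, a 1.7-fold higher number from compound 1 to compound 2 (0.24 log units; within the scatter) and a 6.8-fold lower number from compound 1 to compound 3 (0.84 log units; beyond the scatter). A step within the scatter, or at most a small one in either direction, is therefore expected in this assay. Compound 4 is expected at 10000 nM (range 4000 nM to 30000 nM), the expected step being a 1.3-fold lower number from compound 1 to compound 4 (0.11 log units; within the scatter).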

Compound 4, concentration for 50% growth inhibition: 1400 nM
Compound 4: middle estimate off by 7.1-fold (0.85 log units), on the high side; the measured number lies below the stated range.
By their numbers in this assay, from the lowest: compounds 4 and 3 (each within the scatter of the next); then compounds 1 and 2 (each within the scatter of the next).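

In this assay, going by these compounds alone, chloro meta to a large group gives a 9.3-fold lower number from compound 1 to compound 4 (0.97 log units; beyond the scatter) on the shared core, the first step at this place on the ring. A low number in these compounds therefore does not require a hydroxy group, as a 1.4-fold lower number from compound 3 to compound 4 (0.13 log units; within the scatter) shows, while a 16-fold lower number from compound 2 to compound 4 (1.21 log units; beyond the scatter) leaves the 4-methoxyphenyl compound well apart. No measurement at hand accounts for this shift.

From the compounds shown here alone, whether the step belongs to chloro itself or to its place on the ring remains open. A bromo group or an amine at the same place would help separate the two.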